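This account rests on a few compounds, and the source may have more. Where it says the series, first, only, none or still open, it means among the compounds named here.

For the measured compounds named here, compound 2 `CCCn1c(=O)n(C)c(=O)c2c1ncn2CCO` is the only member with a number in an assay on Cerebral cortex for binding affinity to adenosine receptor A1 (Cavia porcellus), read by radioligand binding (on this read-out lower numbers stand for stronger inhibition and higher numbers for weaker inhibition), where compound 2 gives 41400 nM. Compound 1 `CCCn1c(=O)n(C)c(=O)c2c1ncn2CCN(C)C` reaches only a limit in this assay, reported as > 200000 nM. Going by the values given here, the single measured step, an at least 4.8-fold lower number from compound 1 to compound 2 (0.68 log units; beyond the scatter), concerns a different change and does not bear on lengthening the chain. Compound 3 `CCCn1c(=O)n(C)c(=O)c2c1ncn2CCCO` differs from compound 2 by hydroxymethyl in place of hydroxy on a saturated chain carbon, two bonds along the chain from an aromatic nitrogen. Among the compounds with values here, no measured step tests such a lengthening, so in this assay a step of no size beyond the scatter is expected, a 1.0-fold lower number from compound 2 to compound 3 (0.01 log units; within the scatter). For compound 3 the estimate is 40000 nM, expected between 15000 nM and 110000 nM.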

Compound 3, inhibition constant: 112000 nM
Beside the measured number, compound 3's estimate is 2.8-fold (0.45 log units) below it, outside the stated range (above it).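

In this assay, going from 2-hydroxyethyl to 3-hydroxypropyl gives a modest step, a 2.7-fold higher number from compound 2 to compound 3 (0.43 log units; beyond the scatter), the first measured sign that this position responds to chain length and not only to the exchange of dimethylamino for hydroxy. Keeping the terminal hydroxy group therefore does not by itself keep the number of compound 2. Compound 1 gives only a limit, so an at least 1.7-fold lower number from compound 1 to compound 3 (0.25 log units; that floor lies within the scatter) is a floor and not a measured size: the limit of > 200000 nM in this assay, at which 1 of the 3 values shown sits.

On these data alone, how a longer chain such as 4-hydroxybutyl would read remains open. So does whether a carboxylic acid or a primary amine at the end of the chain would read differently from hydroxy.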